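From 2-Bromophenyl to 3,5-Difluorophenyl: One Swap Awaiting Measurement

A few compounds are considered here, and "the series" means these few. Any claim that something is new, unique, unknown or untested is made for them only; others in the source may bear on it.

Of the compounds shown here, two built on a shared core have been measured in a functional assay on PC-3 cells (Homo sapiens) for inhibition, read by MTT assay, with a stated time of 48 h, tested at 10 uM; on this read-out lower numbers stand for less inhibition of growth and higher numbers for more inhibition of growth at the one concentration tested. Compound 1 (`Cc1cc(=O)c2c(O)c(CN(C(C)C)C(C)C)c(O)c([C@H]3CCN(C)C[C@H]3O)c2o1`) gives 0%. Compound 2 (`Cc1oc2c([C@H]3CCN(C)C[C@H]3O)c(O)cc(O)c2c(=O)c1C(O)c1ccccc1Br`) gives 45%, the higher of the two numbers, and the gap between them lies beyond the scatter.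

Compound 3 (`Cc1oc2c([C@H]3CCN(C)C[C@H]3O)c(O)cc(O)c2c(=O)c1C(O)c1cc(F)cc(F)c1`) has not yet been measured. It differs from compound 2 in one place: 3,5-difluorophenyl in place of 2-bromophenyl on a saturated chain carbon bound to an aromatic carbon and an oxygen on a saturated carbon. In words, 3,5-difluorophenyl stands in place of 2-bromophenyl on a saturated chain carbon bound to an aromatic carbon and an oxygen on a saturated carbon.

Going by the values given here, the two measured compounds differ in more than one place, so they offer no direct precedent for the size of this swap. The expectation therefore starts from compound 2 at 45%, and no step beyond the scatter is foreseen. The estimated change is a number 5 percentage points lower from compound 2 to compound 3 (within the scatter), a slight fall that is expected to stay within the scatter. For compound 3 the estimated value is 40%, with an expected range of 15% to 65%.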

Compound 3, percent growth inhibition at one concentration: 0%
The estimate for compound 3 lay 40 percentage points above the measured number; the whole stated range lies above it.
By their numbers in this assay, from the lowest: compounds 1 and 3 (each within the scatter of the next); then compound 2.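

In this assay, placing 3,5-difluorophenyl in place of 2-bromophenyl on a saturated chain carbon bound to an aromatic carbon and an oxygen on a saturated carbon brings a number 45 percentage points lower from compound 2 to compound 3 (beyond the scatter), a large step. This shows that the position is not indifferent to the substitution of its aryl group: the growth inhibition of compound 2 is lost in compound 3, although both groups hold one six-membered aromatic ring of carbon only and the hydroxyl-bearing carbon and the shared core stay the same. No measurement at hand bears on why the step is so large.

The swap alters the halogen, the number of halogen atoms and their places on the ring all at once, so this single pair cannot tell which of these changes carries the step. As far as these compounds go, whether an unsubstituted phenyl, 2-fluorophenyl or 3,5-dibromophenyl on the same carbon would read like compound 2 or like compound 3 stays open, as does the effect of an amine in place of the hydroxyl on that carbon.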